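Methoxy in place of methyl: compound 2 to compound 3

The compounds below may be only part of what the source reports. "The series", "measured", "known", "first", "only" and "open" are said of these compounds alone.

In a functional assay on HT-29 cells (Homo sapiens) for antiproliferative activity, read by sulforhodamine B assay, with a stated time of 48 h (a higher number here means a weaker inhibitor, a lower number a stronger inhibitor), compound 2 (`CCCN1CCN(c2ccc(S(=O)(=O)Oc3ccccc3C)cc2)C1=O`) gives only a limit of the assay, > 100000 nM. Compound 3 (`CCCN1CCN(c2ccc(S(=O)(=O)Oc3ccccc3OC)cc2)C1=O`) has methoxy in place of methyl on an aromatic carbon, ortho to a large group (methoxy in place of methyl on an aromatic carbon). The 2-methoxyphenyl group also occurs in compound 1 (`COc1ccccc1OS(=O)(=O)c1ccc(N2CCN(C)C2=O)cc1`), which gives 26000 nM in this assay. On that value, the expected change is an at least 3.3-fold lower number from compound 2 to compound 3 (0.52 log units; beyond the scatter), towards stronger inhibition and beyond the scatter, though its size is uncertain. For compound 3 the estimated value is 30000 nM, with an expected range of 8000 nM to 100000 nM.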

Compound 3, half-maximal inhibitory concentration: > 100000 nM
Compound 3 ended at the assay's limit; the forecaster's own chance of this, stated with the estimate: 25%; at least 3.3-fold (0.52 log units) between middle value and limit.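

In this assay, the 2-methoxyphenyl group alone does not keep a readable value: ethyl in place of hydrogen on the saturated chain carbon bound to the amide-type nitrogen in the ring gives an at least 3.8-fold higher number from compound 1 to compound 3 (0.58 log units; beyond the scatter). This chain change therefore matters at least modestly with the 2-methoxyphenyl group in place. The step from methyl to methoxy on the aromatic carbon cannot be read, as both ends are limits of the assay: the limit of > 100000 nM in this assay, at which 2 of the 3 values shown sit.

As far as these compounds go, it remains open how 2-methylphenyl and 2-methoxyphenyl compare on the chain of compound 1. Also open, from the compounds shown here alone, is whether an ethyl chain, or an amine on the chain, would give a value inside the assay's range.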